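This account rests on a few compounds, and the source may have more. Where it says the series, first, only, none or still open, it means among the compounds named here.

Measured so far:
Compound 1, `CCCOc1ccc(-c2cn3c(=O)n(-c4ccccc4)nc3c(N)n2)cc1`: in an assay on cells for displacement of a labelled ligand from adenosine receptor A1 (Homo sapiens), read by scintillation counting, with a stated time of 3 h (on this read-out lower numbers stand for stronger inhibition and higher numbers for weaker inhibition), compound 1 gives > 30000 nM, which is a limit of the assay and not a number.
Compound 2, `COc1ccc(-c2cn3c(=O)n(-c4ccccc4)nc3c(=O)[nH]2)cc1`: in this assay compound 2 gives > 30000 nM, again a limit rather than a number.
Compound 3, `O=c1[nH]c(-c2ccc(O)cc2)cn2c(=O)n(-c3ccccc3)nc12`: in this assay compound 3 gives 616 nM.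

Compound 1 therefore stands at the weak end of what has been measured; its value is a limit, and the limit of > 30000 nM in this assay, at which 2 of the 3 values shown sit, shows how common that outcome is in this small set. Compound 4, `C#CCOc1ccc(-c2cn3c(=O)n(-c4ccccc4)nc3c(N)n2)cc1`, is made from compound 1 by a single change on the side chain, (ethynyl in place of ethyl on a saturated chain carbon bound to an oxygen on an aromatic ring).

Among the compounds with values here, only one measured step is available, an at least 48-fold lower number from compound 2 to compound 3 (1.68 log units; beyond the scatter). It concerns a different change, hydrogen in place of methyl on an oxygen on an aromatic ring, and it sits on compounds whose core differs from that of compound 1. Within the data shown here, it says nothing about swapping ethyl for ethynyl on the chain carbon bound to the oxygen, so no step of a particular size or direction can be read from it for this assay.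

Given that compound 1 gives > 30000 nM, compound 4 is expected to give 30000 nM, within a range from 6000 nM to 100000 nM, and the step of a number no higher from compound 1 to compound 4 (the limit leaves the size open) is expected to be small.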

Compound 4, inhibition constant: > 30000 nM
Compound 4: no number, only a limit; the forecaster's own chance of this, stated with the estimate: 70%; the middle value lies on the limit itself.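

Compound 1 and compound 4 both sit at a limit of the assay rather than at a number, so no step between them can be read: the limit of > 30000 nM in this assay, at which 3 of the 4 values shown sit.

Still open, on these data alone, is how strongly either compound inhibits in this assay, and whether ethynyl in place of ethyl makes any difference there.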